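A few compounds are considered here, and "the series" means these few. Any claim that something is new, unique, unknown or untested is made for them only; others in the source may bear on it.

In a functional assay on L1210 cells (Mus musculus) for antiproliferative activity, with a stated time of 48 h (a lower number here means a stronger inhibitor, a higher number a weaker inhibitor), compound 1 `C=C(Br)C(=O)Nc1ccc(/C=C/C(=O)c2ccccc2)cc1` gives 5000 nM. Going by the values given here, compound 2 `C=C(Br)C(=O)Nc1ccc(/C=C/C(=O)c2ccc(F)cc2)cc1` differs from it only by fluoro in place of hydrogen on an aromatic carbon, and compound 2 gives 1600 nM, the lower of the two numbers measured so far. That single swap produces a 3.1-fold lower number from compound 1 to compound 2 (0.49 log units; beyond the scatter).

The next compound, compound 3 `C=C(Br)C(=O)Nc1ccc(/C=C/C(=O)c2ccc(Cl)cc2)cc1`, keeps everything else and changes that same group: chloro in place of fluoro on an aromatic carbon. In words, chloro takes the place of fluoro on an aromatic carbon, para to a large group.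

Among the compounds with values here, only one measured step bears on this change, and it is not the same swap. It shows that replacing hydrogen at this place can move the number, with a 3.1-fold lower number from compound 1 to compound 2 (0.49 log units; beyond the scatter) as its modest size. Within the data shown here, no measured compound yet carries chloro, so the direction of a change from fluoro to chloro remains open. A small shift in this assay, not beyond the usual scatter, is therefore the expectation, and the estimated step is a 1.1-fold lower number from compound 2 to compound 3 (0.06 log units; within the scatter). For compound 3 the estimated value is 1400 nM, with an expected range from 500 nM to 3500 nM.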

Compound 3, half-maximal inhibitory concentration: 1100 nM
Beside the measured number, compound 3's estimate is 1.3-fold (0.10 log units) above it; measured number inside the range.
By their numbers in this assay, from the lowest: compounds 3 and 2 (each within the scatter of the next); then compound 1.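

Swapping fluoro for chloro on this aromatic carbon, para to a large group, gives only a small step in this assay, (a 1.5-fold lower number from compound 2 to compound 3 (0.16 log units; within the scatter)), so the two halogens cannot be told apart here. Measured against hydrogen, chloro gives a clear step (a 4.5-fold lower number from compound 1 to compound 3 (0.66 log units; beyond the scatter)), so the drop seen with fluoro is no longer a single case: both halogens at this place stand apart from hydrogen, and the choice between them makes little measurable difference. The data shown offer no measurement that explains why either halogen differs from hydrogen.

The compounds shown leave open whether the trend extends beyond these two halogens, since bromo, methyl, methoxy, trifluoromethyl or an amine at this place could each fall in line with them or break away. They also leave open whether a halogen on another carbon of this ring would give a similar step, and whether the same swaps would behave alike on a different core.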